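Methoxy on the anilino ring of compound 2

The source may hold more compounds than are shown below. What is called first, only, known or untested is meant among the compounds shown, and "the series" means these compounds.

Two compounds of this series carry a number in an assay on isolated protein for inhibition of Aromatase (Homo sapiens), with stated times of 1 min and 60 min, tested at 1 uM; a higher number here means more inhibition at the concentration tested (going by the name of the read-out), a lower number less inhibition. Compound 1 `O=C(Nc1ccccc1)OC(COc1ccc(Cl)cc1)Cn1cncn1` gives 46% in this assay. Among the compounds with values here, compound 2 `O=C(Nc1ccccc1)OC(COc1ccccc1)Cn1ccnc1` gives 27% in this assay and stands lowest of the two, with compound 1 the only point of comparison, and that one beyond the scatter above it. Within the data shown here, no pair of measured compounds differs in just one place, so the size that a single change makes in this assay cannot be read from this series yet.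

Compound 3 `COc1ccc(NC(=O)OC(COc2ccccc2)Cn2ccnc2)cc1` is not yet measured. It differs from compound 2 by methoxy in place of hydrogen on an aromatic carbon. The new group sits on a six-membered aromatic ring of carbon only, para to a large group; read one bond further out, anilino becomes (4-methoxyphenyl)amino. Among the measured compounds shown here, nothing measured so far says how such a change moves this assay. The expected step is small, a number 3 percentage points higher from compound 2 to compound 3 (within the scatter), in either direction and within the scatter rather than beyond it. Compound 3 is therefore expected to give about 30% in this assay, within 10% to 55%.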

Compound 3, a percentage reported as inhibition, at one concentration (the size of the read-out at that concentration, not a potency): 61%
The estimate for compound 3 lay 31 percentage points below the measured number, and the stated range ends below it.
By their numbers in this assay, from the lowest: compound 2; then compound 1; then compound 3.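

In this assay the series now has its first comparison of compounds that differ in one place: methoxy in place of hydrogen on an aromatic carbon gives a number 34 percentage points higher from compound 2 to compound 3 (beyond the scatter), a large step. The place on the anilino ring para to a large group is therefore not indifferent to substitution, and going from anilino to (4-methoxyphenyl)amino, with only 2 heavy atoms added, is enough to move the read-out beyond the usual scatter. Nothing at hand bears on why this one change has a step of this size, so the step stands as an observation without a cause.

A single step at a single place cannot show whether the rise belongs to methoxy itself or would come with other groups there, and a hydroxyl, a chlorine or an ethoxy group on the same carbon would separate these cases. From the compounds shown here alone, it also remains open whether (4-methoxyphenyl)amino gives a similar step on the core of compound 1, or whether methoxy on the other aromatic ring of compound 2 moves the number at all.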